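This account rests on a few compounds, and the source may have more. Where it says the series, first, only, none or still open, it means among the compounds named here.

Compound 1 `COc1ccc(/C=N/NC(=O)Nc2ccc(Oc3ccnc(-c4nncn4CCN(C)C)c3)c(F)c2)c(OC)c1OC`: 2020 nM
Compound 2 `CN(C)CCn1cnnc1-c1cc(Oc2ccc(NC(=O)N/N=C/c3cccc(Cl)c3Cl)cc2F)ccn1`: 51 nM
Compound 3 `CN(C)CCn1cnnc1-c1cc(Oc2ccc(NC(=O)N/N=C/c3ccc(F)cc3Cl)cc2F)ccn1`: 870 nM

In a functional assay on MKN-45 cells (Homo sapiens) for cytotoxicity, read by MTT assay, with a stated time of 72 h (on this read-out higher numbers stand for weaker inhibition and lower numbers for stronger inhibition), compound 3 gives 870 nM, the second highest of the three numbers; it lies between compound 1, which gives 2020 nM, and compound 2, which gives 51 nM. Compound 4 `Cc1cc(/C=N/NC(=O)Nc2ccc(Oc3ccnc(-c4nncn4CCN(C)C)c3)c(F)c2)cc(C)c1O` differs from compound 3 in one place: 4-hydroxy-3,5-dimethylphenyl in place of 2-chloro-4-fluorophenyl on a carbon with a double bond to nitrogen. All three measured steps change this same ring: a 40-fold lower number from compound 1 to compound 2 (1.60 log units; beyond the scatter), a 2.3-fold lower number from compound 1 to compound 3 (0.37 log units; beyond the scatter) and a 17-fold higher number from compound 2 to compound 3 (1.23 log units; beyond the scatter). None of them introduces a hydroxy or methyl group, so the direction of the present change is not settled by them; they only show that exchanging this ring can move this assay by large amounts. The entering group brings a hydrogen-bond donor and acceptor, and the closest measured parallel is the 2,3,4-trimethoxyphenyl ring of compound 1, which is expected to be the better guide because compound 1 gives 2020 nM. For compound 4 a modest rise is therefore expected, a 1.7-fold higher number from compound 3 to compound 4 (0.24 log units; within the scatter). Compound 4 is estimated at 1500 nM, within a range from 300 nM to 8000 nM.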

Compound 4, half-maximal inhibitory concentration: 1510 nM
For compound 4 the middle estimate is 1.0-fold (0.00 log units) below the measured one; the range from low to high includes it.
By their numbers in this assay, from the lowest: compound 2; then compounds 3, 4 and 1 (each within the scatter of the next, the first and the last beyond it).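

In this assay the 4-hydroxy-3,5-dimethylphenyl ring cannot be told apart from either of two other rings, with a 1.7-fold higher number from compound 3 to compound 4 (0.24 log units; within the scatter) and a 1.3-fold lower number from compound 1 to compound 4 (0.13 log units; within the scatter), even though compound 3 and compound 1 differ from each other beyond the scatter. The 2,3-dichlorophenyl ring stays clearly separate, with a 30-fold higher number from compound 2 to compound 4 (1.47 log units; beyond the scatter), so adding a hydrogen-bond donor in this ring change does not bring compound 4 close to compound 2. Nothing measured here explains these results.

The compounds shown leave open whether the low number of compound 2 depends on having both chlorines in that arrangement, given that compound 3 also carries a chlorine yet lies far from it. Also open, as far as these compounds go, is how this position would respond to a ring bearing a primary amine or a carboxylic acid.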